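A few compounds are considered here, and "the series" means these few. Any claim that something is new, unique, unknown or untested is made for them only; others in the source may bear on it.

Compound 1 `CCCN(Cc1ccc(OCCN2C(=O)CCC2=O)c(C)c1)[C@@H](CC(=O)O)c1ccc(Cl)cc1` and compound 2 `Cc1cc(CN(CC2CC2)[C@@H](CC(=O)O)c2ccc(Cl)cc2)ccc1OCCN1C(=O)CCC1=O` share one core. In an ADME assay on Caco-2 cells (Homo sapiens) for permeability, read by LC-MS, with a stated time of 2 h (on this read-out higher numbers stand for higher permeability and lower numbers for lower permeability), compound 1 gives 9.3 nm/s, and compound 2 gives 7.3 nm/s. Between them stands one change, (cyclopropyl in place of ethyl on a saturated chain carbon bound to an amine nitrogen), and the step it made was a 1.3-fold lower number from compound 1 to compound 2 (0.11 log units; within the scatter). Compound 3 `CCCN(Cc1ccc(OCCn2c(=O)ccn(C)c2=O)c(C)c1)C(CC(=O)O)c1ccc(Cl)cc1` rests on a second core; the difference between the two cores is not broken down here. In this assay compound 3 gives 3.2 nm/s, the lowest of the three numbers. Compound 4 `Cc1cc(CN(CC2CC2)C(CC(=O)O)c2ccc(Cl)cc2)ccc1OCCn1c(=O)ccn(C)c1=O` has not yet been measured in this assay. It differs from compound 3 by cyclopropyl in place of ethyl on a saturated chain carbon bound to an amine nitrogen, the same change as that between compound 1 and compound 2. Because the earlier step was a 1.3-fold lower number from compound 1 to compound 2 (0.11 log units; within the scatter), the step from compound 3 to compound 4 is expected to be about as large, a 1.2-fold lower number from compound 3 to compound 4 (0.09 log units; within the scatter). On that basis compound 4 is estimated at 2.6 nm/s, between 1.2 nm/s and 5.5 nm/s.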

Compound 4, apparent permeability: 3.7 nm/s
The estimate for compound 4 lay 1.4-fold (0.15 log units) below the measured number; measured number inside the range.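

In this assay, putting cyclopropyl in place of ethyl on the second core gave a small step (a 1.2-fold higher number from compound 3 to compound 4 (0.06 log units; within the scatter)), and set beside the step on the first core it does not stand apart: the same change on two cores in this assay, a 1.3-fold lower number (0.11 log units; within the scatter) from compound 1 to compound 2 and a 1.2-fold higher number (0.06 log units; within the scatter) from compound 3 to compound 4, 1.5-fold (0.17 log units) apart, within the scatter of two such steps. Across these two pairs, then, the change carried from one core to the other without a step beyond the scatter. This does not show that it would carry to any further core, and since neither step lies beyond the scatter, the two pairs do not show that the change moves this read-out at all.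

The compounds shown leave open what a longer chain or a cyclobutyl group would do on the same amine nitrogen. They also leave open how any of these pairs would read with an amide in place of the carboxylic acid.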